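The compounds below may be only part of what the source reports. "The series", "measured", "known", "first", "only" and "open" are said of these compounds alone.

Working notes on the series

For the measured compounds named here, the two measured members are compound 1 `COc1cc(/C=C/C(=O)c2cccc(-n3cc(-c4ccccc4)[nH]c3=O)c2)cc(OC)c1OC` and compound 2 `COc1cc(/C=C/C(=O)c2cccc(-n3cc(-c4ccccc4)[nH]c3=O)c2)ccc1O`, which share one core and differ only in the substitution of the ring that carries the enone. In a functional assay on Malme-3M cells (Homo sapiens) for inhibition (a lower number here means a stronger inhibitor of growth, a higher number a weaker inhibitor of growth), compound 1 gives 1310 nM. In this assay compound 2 gives 2670 nM. Compound 1 therefore holds the lower of the two numbers, and its gap to compound 2 lies beyond the usual scatter of repeated measurements of this kind.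

Compound 3 `COc1cc(/C=C/C(=O)c2cccc(-n3cc(-c4ccc(Cl)cc4)[nH]c3=O)c2)cc(OC)c1OC` has not been measured. It keeps the core and the substitution of compound 1 and differs from it in a single place: chloro in place of hydrogen on an aromatic carbon. Going by the values given here, no pair of measured compounds shows what this change does to growth inhibition; the measured pair concerns a different part of the molecule, so nothing in the present numbers speaks for or against an effect here.

The step from compound 1 to compound 3 expected in this assay is a 1.2-fold lower number from compound 1 to compound 3 (0.08 log units; within the scatter), a small change, not clearly beyond the scatter in either direction. For compound 3 the estimate in this assay is 1100 nM, with a range from 450 nM to 2700 nM.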

Compound 3, concentration for 50% growth inhibition: 18100 nM
Estimate against measurement, compound 3: 16-fold (1.22 log units) below; measured number outside the range, above it.
By their numbers in this assay, from the lowest: compound 1; then compound 2; then compound 3.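

In this assay the change from phenyl to 4-chlorophenyl gives a 14-fold higher number from compound 1 to compound 3 (1.14 log units; beyond the scatter) and so is a large step. The two compounds differ by a single chlorine atom on an aromatic carbon. Until now the series offered no reading at this ring, and this step shows that growth inhibition is not indifferent to what sits on this carbon, para to a large group: hydrogen is clearly preferred here over chloro within this pair. The data offer nothing that accounts for the size of this step, so its cause stays unassigned.

The compounds shown leave open whether the loss belongs to chloro specifically or to any group on this carbon, a question that fluoro, methyl, methoxy, an amine or a carboxylic acid in the same place would address. They also leave open whether chloro on another carbon of this ring behaves the same way, and whether the step carries over to the enone-side substitution of compound 2.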